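Indane Acid Expected After the Benzothiophene Acids

This account rests on a few compounds, and the source may have more. Where it says the series, first, only, none or still open, it means among the compounds named here.

In an assay on isolated protein for agonist activity at Bile acid receptor (Homo sapiens), read by FRET, with a stated time of 2 h (a lower number here means a smaller maximal response, a higher number a larger maximal response), compound 1 `CC(C)c1onc(-c2c(Cl)cccc2Cl)c1COc1ccc(Cn2ccc3ccc(C(=O)O)cc32)cc1` gives 38% and compound 2 `CC(C)c1onc(-c2c(Cl)cccc2Cl)c1COc1ccc(-c2ccc3sc(C(=O)O)cc3c2)cc1` gives 77%. Compound 3 `CC(C)c1onc(-c2c(Cl)cccc2Cl)c1COc1ccc(-c2ccc3sc(C(=O)O)cc3n2)cc1` gives 53% in this assay, the second highest of the three values, sitting between compound 1 and compound 2. Among the compounds with values here, the one single-point step is a number 24 percentage points lower from compound 2 to compound 3 (beyond the scatter). Compound 4 `CC(C)c1onc(-c2c(Cl)cccc2Cl)c1COc1ccc(-c2ccc3c(c2)CC(C(=O)O)C3)cc1` is the next change from compound 3: a group of 12 heavy atoms (10 carbon, 2 oxygen; one five-membered non-aromatic ring of carbon only, one six-membered aromatic ring of carbon only) in place of a group of 12 heavy atoms (8 carbon, 1 nitrogen, 2 oxygen, 1 sulfur; one five-membered aromatic ring with 1 hetero atom, one six-membered aromatic ring with 1 hetero atom), on an aromatic carbon. The nitrogen in the six-membered ring leaves again, as it entered from compound 2 to compound 3, so that step bears on this one and a modest rise is expected, though the acid now sits on a non-aromatic ring. For compound 4 an expected value of 60% is estimated, within 35% to 85%, an expected step of a number 7 percentage points higher from compound 3 to compound 4 (within the scatter).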

Compound 4, largest response reached (Emax), in percent of the reference or control that the assay uses: 75%
Compound 4: middle estimate off by 15 percentage points, on the low side; low and high end bracket the measured number.
By their numbers in this assay, from the lowest: compound 1; then compound 3; then compounds 4 and 2 (each within the scatter of the next).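

In this assay, the 2-carboxy-2,3-dihydro-1H-inden-5-yl group gives a number 22 percentage points higher from compound 3 to compound 4 (beyond the scatter), and set against the 2-carboxy-1-benzothiophen-5-yl group it gives a number 2 percentage points lower from compound 2 to compound 4 (within the scatter). Among these compounds, then, a large maximal response at this place does not depend on sulfur or on an aromatic five-membered ring carrying the acid. No measurement shown here explains the change. From the compounds shown here alone, whether a tetrazole or a primary amide could stand in for the carboxylic acid on the 2,3-dihydro-1H-inden-5-yl group and keep this response remains open.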